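The source may hold more compounds than are shown below. What is called first, only, known or untested is meant among the compounds shown, and "the series" means these compounds.

Measured so far:
- compound 1, `Nc1ccccc1NC(=O)/C=C/c1ccc(Cn2cnc3c(Nc4cccc(Cl)c4)nc(Cl)nc32)cc1`: 35.8%
- compound 2, `Nc1ccccc1NC(=O)c1ccc(Cn2cnc3c(Nc4cccc(OC(F)(F)F)c4)nc(Cl)nc32)cc1`: 1.88%
- compound 3, `CC1CCN(c2nc(Cl)nc3c2ncn3Cc2ccc(C(=O)Nc3ccccc3N)cc2)CC1`: 1.22%

In a functional assay on HepG2 cells (Homo sapiens) for antiproliferative activity, read by CCK-8 assay, with a stated time of 72 h, tested at 2 uM (on this read-out higher numbers stand for a stronger effect at the one concentration tested and lower numbers for a weaker effect), compound 2 gives 1.88%, the second highest of the three numbers. Its nearest neighbour is compound 3, reached by a number 0.7 percentage points lower from compound 2 to compound 3 (within the scatter), a step within the scatter, so the two values cannot be ordered. Its furthest neighbour is compound 1, whose value of 35.8% lies well beyond the scatter above compound 2.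

Compound 4, `Nc1ccccc1NC(=O)/C=C/c1ccc(Cn2cnc3c(Nc4cccc(OC(F)(F)F)c4)nc(Cl)nc32)cc1`, differs from compound 2 in one place: 2-((2-aminophenyl)carbamoyl)ethenyl in place of (2-aminophenyl)carbamoyl on an aromatic carbon, on an aromatic carbon of a six-membered aromatic ring of carbon only, para to a large group. Within the data shown here, no measured step isolates this change. Among the measured compounds shown here, the one measured step, from compound 2 to compound 3, concerns a different part of the shared core and gives no guidance. Compound 1, which carries the 2-((2-aminophenyl)carbamoyl)ethenyl group, also differs from compound 2 at the aryl amine, so its higher value can only be read as a loose hint toward an increase.

Compound 4 is therefore expected to show a rise in this assay, a number 20.1 percentage points higher from compound 2 to compound 4 (beyond the scatter), with wide uncertainty. The value of compound 4 in this assay is estimated at 22%, within a range of 4% to 40%.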

Compound 4, a percentage reported as inhibition, at one concentration (the size of the read-out at that concentration, not a potency): 16.2%
Estimate against measurement, compound 4: 5.8 percentage points above; the measured number falls inside the stated range.
By their numbers in this assay, from the lowest: compounds 3 and 2 (each within the scatter of the next); then compound 4; then compound 1.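

In this assay, among these compounds, the change from (2-aminophenyl)carbamoyl to 2-((2-aminophenyl)carbamoyl)ethenyl, on an aromatic carbon para to a large group, gives a number 14.3 percentage points higher from compound 2 to compound 4 (beyond the scatter); this is the first reading of that change alone, and it shows that this position affects the read-out with trifluoromethoxy held constant. The second step isolates the other difference that the earlier comparison left mixed: trifluoromethoxy in place of chloro gives a number 19.6 percentage points lower from compound 1 to compound 4 (beyond the scatter), so the high value of compound 1 cannot be credited to the ethenyl-containing group alone, and the read-out responds to both places. No available evidence accounts for either step.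

The compounds shown leave open whether the ethenyl-containing group would bring a step of similar size with chloro in place of trifluoromethoxy, or with 4-methylpiperidin-1-yl in place of the substituted phenylamino group. They also leave open how a saturated ethyl chain at the same position, or a methoxy or bromo group in place of chloro, would read in this assay.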